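The compounds below may be only part of what the source reports. "The series", "measured", "known", "first", "only" and "open" are said of these compounds alone.

Working notes on the series, read in a functional assay on U-937 cells (Homo sapiens) for cytotoxicity, read by MTT assay, with a stated time of 3 days; a higher number here means a weaker inhibitor, a lower number a stronger inhibitor. Compound 1 `N#Cc1c(-c2ccccc2)nc(SCc2nc3ccccc3[nH]2)nc1N1CCNCC1` gives 5.81 nM, compound 2 `CN1CCN(c2nc(SCc3nc4ccccc4[nH]3)nc(-c3ccccc3)c2C#N)CC1` gives 6.75 nM, and compound 3 `N#Cc1c(-c2ccccc2)nc(SCc2nc3ccccc3[nH]2)nc1N1CCN(S(=O)(=O)c2ccccc2)CC1` gives 6.2 nM. Compound 3 cannot be separated from the other two: a 1.1-fold higher number from compound 1 to compound 3 (0.03 log units; within the scatter) and a 1.1-fold lower number from compound 2 to compound 3 (0.04 log units; within the scatter) both lie within the scatter.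

The next compound is compound 4 `Cc1ccc(S(=O)(=O)N2CCN(c3nc(SCc4nc5ccccc5[nH]4)nc(-c4ccccc4)c3C#N)CC2)cc1`, with this change: methyl in place of hydrogen on an aromatic carbon. Cut one bond further out, this is phenylsulfonyl to (4-methylphenyl)sulfonyl. Among the compounds with values here, no measured step makes this exact change. The nearest evidence comes from the amine nitrogen in a ring that carries the phenylsulfonyl group in compound 3. There, a 1.2-fold higher number from compound 1 to compound 2 (0.07 log units; within the scatter) and a 1.1-fold higher number from compound 1 to compound 3 (0.03 log units; within the scatter) are both within the scatter, even though the second adds a whole phenylsulfonyl group. Within the data shown here, with only three compounds, this flatness is thin evidence, and it says nothing directly about the aromatic carbon. Even so, no step beyond the scatter is expected, in either direction. The expected step is a 1.0-fold higher number from compound 3 to compound 4 (0.01 log units; within the scatter). For compound 4 the estimated value is 6.3 nM, with an expected range of 3 nM to 13 nM.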

Compound 4, half-maximal inhibitory concentration: 4.1 nM
The estimate for compound 4 lay 1.5-fold (0.19 log units) above the measured number; measured number inside the range.
By their numbers in this assay, from the lowest: compounds 4, 1, 3 and 2 (each within the scatter of the next).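

In this assay, within the data shown here, this is the first direct reading at the aromatic carbon: methyl in place of hydrogen, para to a large group, gives a 1.5-fold lower number from compound 3 to compound 4 (0.18 log units; within the scatter) and does not separate the two compounds. The full (4-methylphenyl)sulfonyl group on the amine nitrogen in a ring also stays within the scatter, with a 1.4-fold lower number from compound 1 to compound 4 (0.15 log units; within the scatter) against hydrogen and a 1.6-fold lower number from compound 2 to compound 4 (0.22 log units; within the scatter) against methyl, so the flat reading at that nitrogen now covers four compounds. No available evidence bears on what lies behind this flatness.

On these data alone, it remains open whether a group other than methyl on this aromatic carbon, such as a carboxylic acid, an amine or a chlorine, would give a step beyond the scatter. The compounds shown also leave the shared core unexplored, as all four carry the same nitrile and the same phenyl.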